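A Phenyl Swap on Compound 3

The compounds below may be only part of what the source reports. "The series", "measured", "known", "first", "only" and "open" are said of these compounds alone.

Within the data shown here, in a functional assay on NCI-H1993 cells (Homo sapiens) for inhibition, read by CCK-8 assay, with a stated time of 72 h (a higher number here means a weaker inhibitor, a lower number a stronger inhibitor), the compounds measured so far read as follows.

- compound 1 `Cn1nccc1-c1cnc2ncn(Cc3ccc4ncccc4c3)c2n1` gives 7910 nM
- compound 2 `CCC(c1cc2cccnc2cc1F)n1cnc2ncc(-c3ccc(C(=O)NC)c(F)c3)nc21` gives "not determined" (no result reported)
- compound 3 `CC(NC/N=C/c1ccnn1C)c1ccc2ncccc2c1` gives 3290 nM

Compound 3 holds the lower of the two numbers available, and its distance from compound 1 lies beyond the scatter. Compound 2 contributes no number to the comparison.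

The next compound to be tested is compound 4 `CC(NC/N=C/c1ccccc1)c1ccc2ncccc2c1`, which carries phenyl in place of 1-methyl-1H-pyrazol-5-yl on a carbon with a double bond to nitrogen. Among the measured compounds shown here, no pair of measured compounds shows what a single change does here, so the expectation rests on compound 3 (3290 nM) alone. No step beyond the scatter is expected in this assay, though a slight drift towards a higher number is thought more likely than the reverse. The estimated change is a 1.4-fold higher number from compound 3 to compound 4 (0.14 log units; within the scatter) and remains uncertain. For compound 4 the expected value is 4500 nM, with an estimated range from 1300 nM to 15000 nM.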

Compound 4, half-maximal inhibitory concentration: 1220 nM
Compound 4: the middle estimate sits 3.7-fold (0.57 log units) above what was measured; measured number below the stated range.
By their numbers in this assay, from the lowest: compound 4; then compound 3; then compound 1.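

In this assay, phenyl in place of 1-methyl-1H-pyrazol-5-yl on a carbon with a double bond to nitrogen gives a 2.7-fold lower number from compound 3 to compound 4 (0.43 log units; beyond the scatter) and is the first single change that can be read among these compounds. It shows that the number responds to the ring held at this place, and that a six-membered aromatic ring of carbon only, with no hydrogen-bond acceptors, gives the lower number here, so the ring nitrogens of the pyrazole are not required for activity in these cells. Nothing available explains why the step runs this way.

This single step cannot show whether the lower number belongs to phenyl itself or would extend to other rings. It leaves open what a pyridine ring, or a phenyl carrying a fluorine or a methoxy group, would give at this place.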